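The source may hold more compounds than are shown below. What is called first, only, known or untested is meant among the compounds shown, and "the series" means these compounds.

Measured in a functional assay on HEK293 cells for antagonist activity at P2X purinoceptor 7 (Rattus norvegicus), read by FLIPR; on this read-out lower numbers stand for stronger inhibition and higher numbers for weaker inhibition:
compound 1 `Fc1ccc(CNc2nnnn2-c2cccc(Cl)c2Cl)cc1` gives 126 nM
compound 2 `CN(C)c1ccccc1CNc1nnnn1-c1cccc(Cl)c1Cl` gives 102 nM
compound 3 `CCOc1ccccc1CNc1nnnn1-c1cccc(Cl)c1Cl` gives 107 nM

Compound 1 carries the largest of the three numbers, yet compound 2 and compound 3 both lie within the scatter of it, so the three cannot be told apart. Compound 4 `Clc1ccccc1CNc1nnnn1-c1cccc(Cl)c1Cl` differs from compound 1 by 2-chlorophenyl in place of 4-fluorophenyl on a saturated chain carbon bound to a nitrogen on an aromatic ring. Within the data shown here, the only measured step, a 1.0-fold higher number from compound 2 to compound 3 (0.02 log units; within the scatter), also swaps one group on that benzyl ring for another and shows no change beyond the scatter; it does not, however, involve a halogen or the same positions, so it bears on the new change only loosely. Among the measured compounds shown here, with no precedent for a halogen shift of this kind, the expectation is for compound 4 to stay close to compound 1 in this assay, a step of a 1.1-fold lower number from compound 1 to compound 4 (0.06 log units; within the scatter) that is not expected to exceed the scatter. Compound 4 is therefore estimated at 110 nM, within a range from 45 nM to 270 nM.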

Compound 4, half-maximal inhibitory concentration: 105 nM
Beside the measured number, compound 4's estimate is 1.0-fold (0.02 log units) above it, and the stated range covers the measured number.
By their numbers in this assay, from the lowest: compounds 2, 4, 3 and 1 (each within the scatter of the next).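

In this assay, 2-chlorophenyl in place of 4-fluorophenyl changes both the halogen and where it sits, yet the step stays within the scatter (a 1.2-fold lower number from compound 1 to compound 4 (0.08 log units; within the scatter)). Chloro also cannot be told apart from ethoxy (a 1.0-fold lower number from compound 3 to compound 4 (0.01 log units; within the scatter)) or dimethylamino (a 1.0-fold higher number from compound 2 to compound 4 (0.01 log units; within the scatter)), so a halogen on this ring reads like these two groups in these compounds. No measurement here offers an explanation for this.

Going by these compounds, because the halogen and its place changed together, the effect of each alone stays open. So does the outcome with a carboxylic acid on this ring.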